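The compounds below may be only part of what the source reports. "The series", "measured", "known", "first", "only" and "open" are said of these compounds alone.

Compound 1, `CCC(C(=O)O)c1nn(Cc2cn3cc(OCC4CC4)c(Cl)cc3n2)c2ccccc2c1=O`, gives 25 nM in a functional assay on HFL1 cells for antagonist activity at sphingosine 1-phosphate receptor 2 (Homo sapiens), read by ELISA, with a stated time of 24 h, in the presence of a further agent that is not named here; on this read-out higher numbers stand for weaker inhibition and lower numbers for stronger inhibition.
Compound 2, `O=C(O)Cn1nc(Cc2cn3cc(OCC4CC4)c(Cl)cc3n2)c2ccccc2c1=O`, gives 275 nM in this assay.

Of the two compounds measured, compound 1 stands at the lower, stronger end, and compound 2 at the higher, weaker end; the gap between them lies beyond the usual scatter. Compound 3, `C[C@H](C(=O)O)c1nn(Cc2cn3cc(OCC4CC4)c(Cl)cc3n2)c2ccccc2c1=O`, has not yet been measured. It keeps the shared core of compound 1 and differs in one place: 1-carboxyethyl in place of 1-carboxypropyl on an aromatic carbon, with one defined stereocentre. Among the measured compounds shown here, no measured pair shows the effect of shortening this carboxy-bearing chain, so only the two values can guide the expectation. Compound 2, which carries the plain carboxymethyl group, is markedly weaker than compound 1, so a shorter chain may cost some activity, but compound 3 keeps a branch at this position and is a single stereoisomer. A modest step toward weaker inhibition from compound 1 to compound 3 is expected, a 1.6-fold higher number from compound 1 to compound 3 (0.20 log units; within the scatter), possibly within the scatter. Compound 3 is therefore estimated at 40 nM, with a likely range from 12 nM to 130 nM.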

Compound 3, half-maximal inhibitory concentration in the sphingosine 1-phosphate receptor 2 assay: 19 nM
Compound 3: the middle estimate sits 2.1-fold (0.32 log units) above what was measured, and the stated range covers the measured number.
By their numbers in the sphingosine 1-phosphate receptor 2 assay, from the lowest: compounds 3 and 1 (each within the scatter of the next); then compound 2.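

Compound 1 and compound 3 cannot be told apart in the sphingosine 1-phosphate receptor 2 assay, a 1.3-fold lower number from compound 1 to compound 3 (0.12 log units; within the scatter), so at this position the 1-carboxypropyl group can give way to the shorter 1-carboxyethyl group with no loss of inhibition beyond the scatter. The two compounds do separate on another property: in a physicochemical assay for solubility, measured as thermodynamic solubility, at pH 7.4 (on this read-out lower numbers stand for lower solubility and higher numbers for higher solubility), compound 1 gives 359 ug/mL and compound 3 gives 892 ug/mL. This single change therefore leaves inhibition within the scatter while going with a real gain in dissolved compound, and that gain rests on the measured pair alone: the measured solubility of compound 1, 359 ug/mL, and of compound 3, 892 ug/mL, a 2.5-fold higher number (0.40 log units; beyond the scatter)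

The compounds shown leave open how far this position can be varied, for instance whether a longer 1-carboxybutyl chain or a primary amide in place of the carboxylic acid would hold the inhibition. They also leave open what the defined stereocentre of compound 3 contributes, since the opposite stereoisomer of the 1-carboxyethyl group is not among them and the stereocentre of compound 1 is undefined.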